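This account rests on a few compounds, and the source may have more. Where it says the series, first, only, none or still open, it means among the compounds named here.

Working notes on the series. Three compounds have a number in a functional assay on DLD-1 cells (Homo sapiens) for cytotoxicity, read by colorimetric assay and MTT assay, with a stated time of 3 days, tested at 20 uM; on this read-out lower numbers stand for a stronger effect and higher numbers for a weaker effect at the one concentration tested. Compound 1 `Cc1ccccc1-n1cc(-c2ccccc2)c(-c2ccc3c(c2)NC(=O)CO3)n1` gives 62.9% in this assay. Among the measured compounds shown here, compound 3 `O=C1COc2ccc(-c3nn(-c4ccccc4)cc3-c3ccccc3)cc2N1`, with hydrogen in place of methyl on an aromatic carbon, gives 47.7%; the step of a number 15.2 percentage points lower from compound 1 to compound 3 (beyond the scatter) is the only one-place change measured so far. Compound 2 `O=C1COc2ccc(-c3[nH]c(-c4c[nH]c5ncccc45)nc3-c3ccccc3)cc2N1` gives 53.5%, a number that lies within the scatter of the number for compound 3 and within the scatter of the number for compound 1, so compound 2 cannot be separated from either on the data shown.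

Compound 4 `O=C1COc2ccc(-c3[nH]c(-c4ccc(C(F)(F)F)cc4)nc3-c3ccccc3)cc2N1` has no number yet in this assay. Relative to compound 2 the change is a group of 10 heavy atoms (7 carbon, 3 fluorine; one six-membered aromatic ring of carbon only) in place of a group of 9 heavy atoms (7 carbon, 2 nitrogen; one five-membered aromatic ring with 1 hetero atom, one six-membered aromatic ring with 1 hetero atom), on an aromatic carbon. For the measured compounds named here, no measured step touches this kind of exchange; the step from compound 1 to compound 3 concerns only the loss of a methyl and gives no guide here. The expectation for compound 4 therefore rests on compound 2 alone and carries a wide range. No step beyond the scatter is expected, and the estimated step is a number 1.5 percentage points lower from compound 2 to compound 4 (within the scatter). Compound 4 is expected to give 52%, with an estimated range from 35% to 70%.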

Compound 4, a percentage reported as activity, at one concentration (the size of the read-out at that concentration, not a potency): 12.1%
Beside the measured number, compound 4's estimate is 39.9 percentage points above it; the whole stated range lies above it.
By their numbers in this assay, from the lowest: compound 4; then compounds 3, 2 and 1 (each within the scatter of the next, the first and the last beyond it).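

At this place, on an aromatic carbon of a five-membered aromatic ring with 2 nitrogen, between two ring nitrogen atoms, the exchange of the group of 9 heavy atoms for 4-(trifluoromethyl)phenyl gives a number 41.4 percentage points lower from compound 2 to compound 4 (beyond the scatter) in this assay. Among the compounds shown here, the earlier one-place step concerned only the loss of a methyl on another core, so this is the first sign that the group on this carbon can move the read-out by a large step, and that a group with 0 hydrogen-bond donors and 0 hydrogen-bond acceptors is accepted here in place of one with 1 of each. For the compounds shown here, nothing available explains the size of this step, and the single exchange changes the ring system, the hetero atoms and the trifluoromethyl group all at once.

On these data alone, it remains open whether the step belongs to the trifluoromethyl group or to the six-membered carbon ring, a question that plain phenyl or 4-chlorophenyl at this carbon would address. Also open, as far as these compounds go, is how this place responds to an amine or a carboxylic acid on that ring, and whether the result at one concentration carries over to a full potency measurement.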